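Working notes: from compound 2 to compound 4

The source may hold more compounds than are shown below. What is called first, only, known or untested is meant among the compounds shown, and "the series" means these compounds.

Measured compounds, all in a functional assay on PC-3 cells (Homo sapiens) for cytotoxicity, read by MTT assay, with a stated time of 48 h; on this read-out higher numbers stand for weaker inhibition and lower numbers for stronger inhibition:
Compound 1 `Cc1nc(-c2c[nH]c3ccccc23)co1` gives 337000 nM.
Compound 2 `COc1ccc(-c2nc(-c3c[nH]c4ccccc34)co2)cc1OC` gives 359000 nM.
Compound 3 `C(=C/c1nc(-c2c[nH]c3ccccc23)co1)\c1ccccc1` gives 221000 nM.

The three numbers lie within the usual scatter of one another. Compound 2 has the number nearest to that of compound 1 and furthest from that of compound 3, yet both gaps are within the scatter, so no ranking among the three can be read from these data. Changing the substituent on the shared core from a methyl to a dimethoxyphenyl or to a styryl group leaves the read-out in this assay unchanged within the scatter.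

Compound 4 `COc1ccc(-c2nc(-c3c[nH]c4ccccc34)co2)cc1` differs from compound 2 by hydrogen in place of methoxy on an aromatic carbon. Since compound 1, compound 2 and compound 3 give indistinguishable numbers despite much larger changes at this position, the expectation for this smaller change is a step of no size beyond the scatter, in no preferred direction. The expected step in this assay from compound 2 to compound 4 is a 1.0-fold lower number from compound 2 to compound 4 (0.01 log units; within the scatter). Compound 4 is therefore estimated at 350000 nM in this assay, with a range from 150000 nM to 800000 nM.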

Compound 4, half-maximal inhibitory concentration: 133000 nM
The estimate for compound 4 lay 2.6-fold (0.42 log units) above the measured number; the measured number lies below the stated range.
By their numbers in this assay, from the lowest: compounds 4, 3, 1 and 2 (each within the scatter of the next, the first and the last beyond it).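

In this assay, for the compounds shown here, hydrogen in place of methoxy on an aromatic carbon gives a 2.7-fold lower number from compound 2 to compound 4 (0.43 log units; beyond the scatter) and is the first single change to lie beyond the scatter, though the step is modest. The earlier compounds shown here showed no response even to large changes of the substituent on the shared core, whereas this pair shows that the read-out can move with the loss of one methoxy group, at the place ortho to a methoxy group and meta to a large group. The series is therefore not flat at this aromatic ring, and the methoxy group at this place is not neutral in this assay, but nothing available bears on the reason for the step.

The compounds shown leave open whether the step is specific to removing methoxy at this place or whether other replacements there, such as a hydroxyl, an amine or a longer alkoxy chain, would move the number as well. They also leave open what replacing the remaining methoxy group with hydrogen would do, so one pair cannot yet support a trend across the ring.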